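This account rests on a few compounds, and the source may have more. Where it says the series, first, only, none or still open, it means among the compounds named here.

Working notes on the benzoate series.

Compound 1 `CC1=CC[C@H](C(C)C)c2cc(C)c(OC(=O)c3ccccc3)cc21` is the reference point here. In a functional assay on SK-LU-1 cells (Homo sapiens) for antiproliferative activity, read by sulforhodamine B assay, with a stated time of 48 h, tested at 50 uM (a higher number here means more inhibition at the concentration tested (going by the name of the read-out), a lower number less inhibition), compound 1 gives 37%. This is the second highest of the three numbers recorded; the nearest is compound 3 `COc1ccc(C(=O)Oc2cc3c(C)ccc(C(C)C)c3cc2C)cc1`, which in this assay gives 32.8%, a number within the usual scatter of compound 1. The furthest is compound 2 `Cc1cc2c(C(C)C)ccc(C)c2cc1OC(=O)c1ccc([N+](=O)[O-])cc1`, which in this assay gives 100%, well beyond the scatter.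

Within the data shown here, the one measured step between single-change neighbours is a number 67.2 percentage points lower from compound 2 to compound 3 (beyond the scatter). Among the measured compounds shown here, that step concerns a methoxy group in place of a nitro group on the benzoate ring and is the only guide to how a change on that ring can move the number; it is large.

Compound 4 `CC1=CC[C@H](C(C)C)c2cc(C)c(OC(=O)c3cccc(C)c3)cc21` differs from compound 1 as follows: methyl in place of hydrogen on an aromatic carbon. For the measured compounds named here, no measured step covers a methyl group entering on an aromatic carbon of this ring, meta to a large group. Going by the values given here, the change is small in what it adds, and nothing among the measured compounds points to a shift in either direction, so no step beyond the scatter is expected for this assay.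

The expected step is a number 3 percentage points higher from compound 1 to compound 4 (within the scatter). Compound 4 is estimated at 40%, with a range from 20% to 65%.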

Compound 4, a percentage reported as inhibition, at one concentration (the size of the read-out at that concentration, not a potency): "not active" (no number reported)
For compound 4 the study gives words and no number, and the estimate cannot be compared.
By their numbers in this assay, from the lowest: compounds 3 and 1 (each within the scatter of the next); then compound 2.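

Among these compounds, compound 4 is recorded in this assay only in words, as not active, so no step from compound 1 can be read. The compounds shown leave open how the change from phenyl to 3-methylphenyl moves the number. No measured evidence bears on this result.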